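Same tail exchange on two different linkers

The source may report more compounds than this note shows. Statements on the series, on what has been measured and on what is new or still open speak of the compounds shown alone.

Compound 1 `O=C(NCCCCCCCCCCNc1ncnc2c1ncn2[C@@H]1O[C@H](CO)[C@@H](O)[C@H]1O)C1=CC2C=CC1CC2` and compound 2 `OC[C@H]1O[C@@H](n2cnc3c(NCCCCCCCCCCN=C=S)ncnc32)[C@H](O)[C@@H]1O` share the core of compound 1 and differ by a group of 3 heavy atoms (1 carbon, 1 nitrogen, 1 sulfur; no ring) in place of a group of 11 heavy atoms (9 carbon, 1 nitrogen, 1 oxygen; 2 six-membered non-aromatic rings of carbon only), on a saturated chain carbon, ten or more bonds along the chain from a nitrogen on an aromatic ring. In an assay on Flp-In-CHO cells for agonist activity at adenosine receptor A1 (Homo sapiens), read by ERK phosphorylation, with a stated time of 5 min (a lower number here means a smaller maximal response, a higher number a larger maximal response), compound 1 gives 49% and compound 2 gives 84%, a step of a number 35 percentage points higher from compound 1 to compound 2 (beyond the scatter). Compound 3 `O=C(NCc1ccc(Nc2ncnc3c2ncn3[C@@H]2O[C@H](CO)[C@@H](O)[C@H]2O)cc1)C1=CC2C=CC1CC2` carries another core; how it differs from compound 1 is not broken down here. In this assay compound 3 gives 96%, the highest of the three. Compound 4 `OC[C@H]1O[C@@H](n2cnc3c(Nc4ccc(CN=C=S)cc4)ncnc32)[C@H](O)[C@@H]1O` differs from compound 3 by a group of 3 heavy atoms (1 carbon, 1 nitrogen, 1 sulfur; no ring) in place of a group of 11 heavy atoms (9 carbon, 1 nitrogen, 1 oxygen; 2 six-membered non-aromatic rings of carbon only), on a saturated chain carbon bound to an aromatic carbon, the same kind of change as between compound 1 and compound 2, though here the saturated chain carbon is bound to an aromatic carbon, a different place from that of the change between compound 1 and compound 2. Compound 4 is expected near 100%, within 90% to 110%, because compound 3 already gives 96% close to the full response. The expected step is therefore small, a number 4 percentage points higher from compound 3 to compound 4 (within the scatter).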

Compound 4, largest response reached (reported as percent of maximum), in percent of the reference or control that the assay uses: 101%
Beside the measured number, compound 4's estimate is 1 percentage points below it; low and high end bracket the measured number.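

Exchanging the group of 11 heavy atoms for the group of 3 heavy atoms does not carry over in size from one core to the other in this assay: the same change on two cores in this assay, a number 35 percentage points higher (beyond the scatter) from compound 1 to compound 2 and a number 5 percentage points higher (within the scatter) from compound 3 to compound 4, 30 percentage points apart, beyond the scatter of two such steps

On the second core the exchange gives a number 5 percentage points higher from compound 3 to compound 4 (within the scatter), so this pair shows no change in maximal response. The two steps show that the size of the step depends on the core, but not which feature of the core is responsible, since the linker differs and so does the starting value, with compound 1 at 49% and compound 3 at 96%.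

Open, from the compounds shown here alone, is whether another end group, such as an amine or a carboxylic acid, would behave alike on both cores. Also open, going by these compounds, is whether a shorter chain on the core of compound 1 would bring its step closer to the other.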